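Notes on the carboxy analogue of compound 1

This account rests on a few compounds, and the source may have more. Where it says the series, first, only, none or still open, it means among the compounds named here.

compound 1 `CN1CCN(C(=O)/C=C/c2ccncc2-c2ccc3ccccc3c2)CC1` gives > 10000 nM
compound 2 `NNC(=O)CCc1ccncc1-c1ccc2ccccc2c1` gives > 10000 nM
compound 3 `CNC(=O)/C=C/c1ccncc1-c1ccc2cc[nH]c2c1` gives 9230 nM
compound 4 `O=C(O)/C=C/c1ccncc1-c1ccc2ccccc2c1` has no value yet

For the measured compounds named here, all readings come from a functional assay on MCF7 cells (Homo sapiens) for inhibition, read by sulforhodamine B assay, with a stated time of 72 h (a higher number here means a weaker inhibitor of growth, a lower number a stronger inhibitor of growth), and the series so far shows the limit of > 10000 nM in this assay, at which 2 of the 3 values shown sit, as its main feature. Compound 1 gives only a limit (> 10000 nM), not a number. Compound 4 differs from it by hydroxy in place of 4-methylpiperazin-1-yl on a carbonyl carbon with hydroxy in place of 4-methylpiperazin-1-yl on a carbonyl carbon, so (4-methylpiperazin-1-yl)carbonyl becomes carboxy. Going by the values given here, no measured pair shows this change. With compound 1 as the reference (> 10000 nM), no step beyond the scatter is expected in this assay in either direction. The expected change is (a step that the limit leaves unreadable from compound 1 to compound 4). For compound 4 the estimated value is 15000 nM (expected range 6000 nM to 40000 nM).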

Compound 4, concentration for 50% growth inhibition: > 10000 nM
Compound 4 was reported as a limit; the forecaster's own chance of this, stated with the estimate: 65%; the middle value is on the limit's open side.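

In this assay compound 4 gives > 10000 nM, a limit, so the steps from compound 1 and from compound 2 to compound 4 cannot be read. Whether carboxy or (4-methylpiperazin-1-yl)carbonyl gives the stronger inhibitor of growth stays open, with most of the series resting on one reading: the limit of > 10000 nM in this assay, at which 3 of the 4 values shown sit.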